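The compounds below may be only part of what the source reports. "The series", "measured", "known", "first", "only" and "open" are said of these compounds alone.

Measured in a functional assay on SW-620 cells (Homo sapiens) for inhibition, read by MTT assay, with a stated time of 72 h; on this read-out lower numbers stand for stronger inhibition and higher numbers for weaker inhibition:
Compound 1 `COc1cc(NC(C)CCCNC(=O)Nc2ccc(F)cc2)c2ncccc2c1`: 25000 nM
Compound 2 `COc1cc(NC(C)CCCNC(=O)Nc2cccc(C(F)(F)F)c2)c2ncccc2c1`: 22000 nM

Compound 2, at 22000 nM, stands level with compound 1 within the scatter. Compound 3 `COc1cc(NC(C)CCCNC(=O)Nc2ccc(O)cc2)c2ncccc2c1` keeps the shared core and carries 4-hydroxyphenyl in place of 3-(trifluoromethyl)phenyl on an amide-type nitrogen. Among the compounds with values here, the one measured step at this nitrogen, a 1.1-fold lower number from compound 1 to compound 2 (0.06 log units; within the scatter), stayed within the scatter, though no measured compound carries 4-hydroxyphenyl. No change beyond the scatter is therefore expected in this assay. The expected step is a 1.1-fold lower number from compound 2 to compound 3 (0.04 log units; within the scatter). Compound 3 is estimated at 20000 nM, with an expected range from 8000 nM to 50000 nM.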

Compound 3, half-maximal inhibitory concentration: 30000 nM
Beside the measured number, compound 3's estimate is 1.5-fold (0.18 log units) below it; the measured number falls inside the stated range.
By their numbers in this assay, from the lowest: compounds 2, 1 and 3 (each within the scatter of the next).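

In this assay the swap to 4-hydroxyphenyl in place of 3-(trifluoromethyl)phenyl on the amide-type nitrogen gives a 1.4-fold higher number from compound 2 to compound 3 (0.13 log units; within the scatter) and hydroxy in place of fluoro on an aromatic carbon gives a 1.2-fold higher number from compound 1 to compound 3 (0.08 log units; within the scatter) so that neither step leaves the scatter. A ring carrying a hydrogen-bond donor therefore stands level with the fluoro and trifluoromethyl rings at this position, which the first pair, both without such a donor, could not show. No measured evidence accounts for this flat result. 

From the compounds shown here alone, it stays open whether an amine, a carboxylic acid or a longer chain on the ring would move the number beyond the scatter. Going by these compounds, it also stays open whether any change at this nitrogen matters in this assay.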